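The source may hold more compounds than are shown below. What is called first, only, known or untested is meant among the compounds shown, and "the series" means these compounds.

For the measured compounds named here, compound 1 `C=CCn1c(=O)/c(=C\c2cccc(C)c2)[nH]c(=O)/c1=C\c1ccccc1OC` is the only member of this small set with a numerical reading: in a functional assay on BGC-823 cells (Homo sapiens) for cytotoxicity, read by CCK-8 assay, with a stated time of 72 h (on this read-out higher numbers stand for weaker inhibition and lower numbers for stronger inhibition), compound 1 gives 20400 nM, which places it at the weak end of what the assay resolves. Compound 2 `COc1ccccc1/C=c1/[nH]c(=O)/c(=C\c2ccccc2OC)[nH]c1=O`, which carries the 2-methoxyphenyl arm on both exocyclic double bonds and lacks the allyl substituent, is recorded in this assay only as "not active" (no number reported), with no number attached, so it offers no scale for comparison. Compound 3 `C=CCn1c(=O)/c(=C\c2ccc(F)c(Br)c2)[nH]c(=O)/c1=C\c1ccccc1OC` keeps the core and the allyl group of compound 1 and changes one arm: 3-bromo-4-fluorophenyl in place of 3-methylphenyl on a double-bonded chain carbon bound to an aromatic carbon. Going by the values given here, no measured pair in the data isolates such a swap, so the size of its effect is unknown. Since compound 1 sits at 20400 nM and the change keeps the ring size and the count of donors and acceptors, the step is expected to stay small, with the direction uncertain. The expected step of a 1.4-fold lower number from compound 1 to compound 3 (0.13 log units; within the scatter) is therefore taken as near zero, within the ordinary scatter. Compound 3 is accordingly estimated at 15000 nM, with a plausible range from 5000 nM to 50000 nM.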

Compound 3, half-maximal inhibitory concentration: "not active" (no number reported)
Compound 3 has no reported number here, so the estimate cannot be set against anything.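

For the compounds shown here, compound 3, like compound 2, is recorded in this assay as not active without a number, so no step from compound 1 can be read. Nothing shown bears on why compound 3 carries this record. The compounds shown leave open how far 3-bromo-4-fluorophenyl in place of 3-methylphenyl moves the reading.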